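The source may hold more compounds than are shown below. What is called first, only, known or untested is meant among the compounds shown, and "the series" means these compounds.

Measured in a functional assay on HCT-116 cells (Homo sapiens) for antiproliferative activity, read by sulforhodamine B assay, with a stated time of 72 h; on this read-out higher numbers stand for weaker inhibition and lower numbers for stronger inhibition:
- compound 1 `Cn1ncc(Cl)c1-c1cc(C(=O)N[C@@H]2CN[C@H](CCNS(C)(=O)=O)C[C@H]2c2ccc(F)c(F)c2)oc1Cl`: 920 nM
- compound 2 `Cn1ncc(Cl)c1-c1cc(C(=O)N[C@@H]2CN[C@H](CCN3CCC(O)CC3)C[C@H]2c2ccc(Cl)c(Cl)c2)oc1Cl`: 13700 nM
- compound 3 `Cn1ncc(Cl)c1-c1cc(C(=O)N[C@@H]2CNCC[C@H]2c2ccc(C(F)(F)F)cc2)oc1Cl`: 280 nM

Of these three, compound 2 stands highest at 13700 nM, so it is the weakest inhibitor here. The gaps to the other two lie beyond the usual scatter of such measurements, with compound 1 nearer to it and compound 3 furthest away.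

The next compound, compound 4 `CN(C)CC[C@@H]1C[C@@H](c2ccc(Cl)c(Cl)c2)[C@H](NC(=O)c2cc(-c3c(Cl)cnn3C)c(Cl)o2)CN1`, has dimethylamino in place of 4-hydroxypiperidin-1-yl on a saturated chain carbon, two bonds along the chain from a saturated ring carbon.

Among the measured compounds shown here, no pair of measured compounds shows this change on its own, so the expectation rests on thin evidence. Compound 2 at 13700 nM has the highest number of the three, which leaves more room to fall than to rise. A moderate move towards stronger inhibition in this assay is therefore expected, somewhat beyond the scatter, and no change at all cannot be excluded.

The expected step is a 3.4-fold lower number from compound 2 to compound 4 (0.53 log units; beyond the scatter).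

Compound 4 is estimated at 4000 nM, with an expected range from 1000 nM to 14000 nM.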

Compound 4, half-maximal inhibitory concentration: 1710 nM
Compound 4: middle estimate off by 2.3-fold (0.37 log units), on the high side, and the stated range covers the measured number.
By their numbers in this assay, from the lowest: compound 3; then compounds 1 and 4 (each within the scatter of the next); then compound 2.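

In this assay the change to dimethylamino in place of 4-hydroxypiperidin-1-yl, on a saturated chain carbon, two bonds along the chain from a saturated ring carbon, gives an 8.0-fold lower number from compound 2 to compound 4 (0.90 log units; beyond the scatter) and so lies beyond the scatter. Among the compounds shown here, this is the first comparison in the set that differs in one place only, and it shows that the group carried on the 2-substituted ethyl chain can alone shift the antiproliferative read-out, with the smaller, ring-free group giving the lower number. No measurement at hand accounts for this step.

For the compounds shown here, the single pair cannot separate the loss of the ring from the loss of the hydroxyl or of the heavy atoms. The compounds shown leave open how a plain piperidin-1-yl, a morpholin-4-yl or a primary amine would read here, and what a longer chain would do.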